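A few compounds are considered here, and "the series" means these few. Any claim that something is new, unique, unknown or untested is made for them only; others in the source may bear on it.

In a functional assay on HL-60 cells (Homo sapiens) for cytotoxicity, read by MTT assay, with a stated time of 72 h (a lower number here means a stronger inhibitor, a higher number a weaker inhibitor), compound 1 `COc1cc(Nc2nc3ccccc3nc2S(=O)(=O)c2ccc(C)cc2)cc(OC)c1` gives 20 nM and compound 2 `Cc1ccc(S(=O)(=O)c2nc3ccccc3nc2Nc2ccc(N)cc2)cc1` gives 1220 nM as the higher of the two numbers, which makes it the weaker inhibitor of the pair. Compound 3 `Nc1ccc(Nc2nc3ccccc3nc2S(=O)(=O)c2ccc(F)cc2)cc1` has not yet been measured. It departs from compound 2 by a single change, fluoro in place of methyl on an aromatic carbon with fluoro in place of methyl on an aromatic carbon, so that 4-methylphenyl becomes 4-fluorophenyl. Among the measured compounds shown here, the only measured step, a 61-fold higher number from compound 1 to compound 2 (1.79 log units; beyond the scatter) and large, is 4-aminophenyl in place of 3,5-dimethoxyphenyl on a nitrogen on an aromatic ring. For the measured compounds named here, it lies at another place in the molecule, and no measured compound varies the 4-methylphenyl group, so the data give no direct guide to this change. The expectation therefore rests on compound 2 at 1220 nM as the anchor, with no step beyond the scatter and no favoured direction foreseen. The expected size is a 1.1-fold lower number from compound 2 to compound 3 (0.04 log units; within the scatter) and no larger. For compound 3 in this assay the estimated value is 1100 nM with an expected range of 350 nM to 3500 nM around it.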

Compound 3, half-maximal inhibitory concentration: 1620 nM
Compound 3: middle estimate off by 1.5-fold (0.17 log units), on the low side; measured number inside the range.
By their numbers in this assay, from the lowest: compound 1; then compounds 2 and 3 (each within the scatter of the next).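

In this assay the exchange of methyl for fluoro on an aromatic carbon, para to a large group, gives a 1.3-fold higher number from compound 2 to compound 3 (0.12 log units; within the scatter) and so leaves compound 2 and compound 3 indistinguishable. Among the compounds shown here, the earlier pair varied only the group on the nitrogen and gave a 61-fold higher number from compound 1 to compound 2 (1.79 log units; beyond the scatter) with that change, whereas this pair is the first reading of the other end of the molecule. With 4-aminophenyl on the nitrogen, 4-methylphenyl and 4-fluorophenyl read alike, and nothing measured bears on why they do so.

As far as these compounds go, whether the two groups also read alike with 3,5-dimethoxyphenyl on the nitrogen, the group that compound 1 at 20 nM carries, remains open, as this position has been read only with 4-aminophenyl in place. Also open, from the compounds shown here alone, is whether this position tolerates only small groups such as methyl and fluoro, or whether a methoxy, a nitrile, a carboxylic acid or a longer alkyl chain there would produce a step beyond the scatter.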